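Bromo for methyl on the aryl ring of a cyclic hydrazide

A few compounds are considered here, and "the series" means these few. Any claim that something is new, unique, unknown or untested is made for them only; others in the source may bear on it.

Measured compounds:
compound 1 `Cc1ccccc1N1CCCC(=O)N1` 57000 nM
compound 2 `Cc1cccc(N2CCCC(=O)N2)c1` 3400 nM
compound 3 `Cc1ccc(N2CCCC(=O)N2)cc1` 277000 nM

In an assay on isolated protein for inhibition of Polyunsaturated fatty acid 5-lipoxygenase (Homo sapiens) (a higher number here means a weaker inhibitor, a lower number a stronger inhibitor), compound 2 shows the lowest number of the three. Compound 1 gives 57000 nM, a gap beyond the scatter, and compound 3 gives 277000 nM, further still. Compound 4 `O=C1CCCN(c2cccc(Br)c2)N1` has not been measured. It differs from compound 2 by bromo in place of methyl on an aromatic carbon. For the measured compounds named here, no measured pair shows this exchange, so the expected step rests on the size of the groups alone: a step from compound 2 to compound 4 of a 1.4-fold lower number from compound 2 to compound 4 (0.13 log units; within the scatter) is expected, within the scatter or slightly downward. Compound 4 is accordingly estimated at 2500 nM, with a range from 800 nM to 8000 nM.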

Compound 4, half-maximal inhibitory concentration: 1800 nM
Estimate against measurement, compound 4: 1.4-fold (0.14 log units) above, and the stated range covers the measured number.
By their numbers in this assay, from the lowest: compounds 4 and 2 (each within the scatter of the next); then compound 1; then compound 3.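

In this assay, bromo in place of methyl on an aromatic carbon gives a 1.9-fold lower number from compound 2 to compound 4 (0.28 log units; within the scatter). The earlier compounds shown here showed only that moving the methyl around the ring matters; this pair shows that, at the place held in compound 2, the methyl can give way to bromo with no change beyond the scatter. No measurement available here bears on why the two groups read alike.

As far as these compounds go, whether bromo would likewise match methyl on the rings of compound 1 and compound 3 stays open. So does how a methoxy group, an amine or a carboxylic acid would read at the place held in compound 4.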